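Cytotoxicity of a Double-Bond Isomer: Compound 4

The compounds below may be only part of what the source reports. "The series", "measured", "known", "first", "only" and "open" are said of these compounds alone.

Measured so far in an ADME assay on HFF cells (Homo sapiens) for cytotoxicity, read by neutral red uptake; on this read-out higher numbers stand for lower toxicity in this test and lower numbers for higher toxicity in this test:
compound 1 `Nc1nc2c(ncn2/C=C2\C[C@@H]2[C@@H](O)CO)c(=O)[nH]1` gives > 300000 nM.
compound 2 `Nc1ncnc2c1ncn2/C=C1/C[C@@H]1[C@@H](O)CO` gives > 300000 nM.
compound 3 `Nc1ncnc2c1ncn2/C=C1\C[C@@H]1[C@@H](O)CO` gives > 300000 nM.

Each of these values is a limit of this assay and not a number. On these data alone, for compound 1 there is only that limit, (the limit of > 300000 nM in this assay, at which 3 of the 3 values shown sit), so its true position is unknown. Compound 4 `Nc1nc2c(ncn2/C=C2/C[C@@H]2[C@@H](O)CO)c(=O)[nH]1` has not yet been measured; (the two compounds have the same atoms and bonds and differ only in configuration as drawn: 1 of 3 stereo elements differ; a double bond is drawn E in compound 1 and Z in compound 4). Within the data shown here, the one measured step of the same kind is a step that the two limits leave unreadable from compound 2 to compound 3, the pair described by the fact that compounds 2 and 3 differ only in the configuration as drawn, and its size cannot be read. No step beyond the scatter in this assay is therefore expected, and the expected step that the limit leaves unreadable from compound 1 to compound 4 is essentially nil. Compound 4 is expected to give 500000 nM, estimated between 300000 nM and 1000000 nM.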

Compound 4, half-maximal cytotoxic concentration: > 300000 nM
Compound 4 gave a limit, no number (the forecaster's own chance of this, stated with the estimate: 85%); the middle value does not contradict the limit.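

Among these compounds, compound 1 and compound 4 each give a limit and not a number, and no step between them can be read. The compounds shown leave open whether the configuration of the double bond matters for toxicity in this test: none of them gives a number.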